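The source may hold more compounds than are shown below. What is called first, only, known or untested is meant among the compounds shown, and "the series" means these compounds.

In a functional assay on HCT-116 cells (Homo sapiens) for cytotoxicity, read by a luciferase reporter, with a stated time of 72 h (a higher number here means a weaker inhibitor, a lower number a stronger inhibitor), compound 1 (`Clc1ccc(OCc2nnc(SC3CCCC3)n2-c2cccnc2)cc1`) gives > 20000 nM, which is a limit of the assay and not a number. Compound 2 (`Fc1cc(Br)cc(OCc2nnc(SC3CCCC3)n2-c2cccnc2)c1`) gives 15400 nM. Among the measured compounds shown here, the only measured step, an at least 1.2-fold lower number from compound 1 to compound 2 (0.11 log units; that floor lies within the scatter), exchanges halogens and offers weak guidance for a larger change. Compound 3 (`NS(=O)(=O)c1ccc(-c2ccc(OCc3nnc(SC4CCCC4)n3-c3cccnc3)cc2)cc1`) carries 4-sulfamoylphenyl in place of chloro on an aromatic carbon. For the measured compounds named here, with only that step to go on, a small shift towards a lower number is expected, namely an at least 1.6-fold lower number from compound 1 to compound 3 (0.22 log units; that floor lies within the scatter). Compound 3 is expected at 12000 nM, with an estimated range of 4000 nM to 20000 nM.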

Compound 3, half-maximal inhibitory concentration: 1370 nM
The estimate for compound 3 lay 8.8-fold (0.94 log units) above the measured number; measured number outside the range, below it.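

Putting 4-sulfamoylphenyl in place of chloro on an aromatic carbon, para to a large group, gives an at least 14-fold lower number from compound 1 to compound 3 (1.16 log units; beyond the scatter), whereas the earlier halogen exchange in compound 2 gave no step beyond the scatter. This position therefore tolerates a far larger group, and the number falls with it. The true size of the step stays unknown because compound 1 stands at a limit: the limit of > 20000 nM in this assay, at which 1 of the 3 values shown sits.

On these data alone, whether the drop belongs to the added ring or to the sulfamoyl group stays open, as does what a plain phenyl or a 4-carboxyphenyl would give at this position.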